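A few compounds are considered here, and "the series" means these few. Any claim that something is new, unique, unknown or untested is made for them only; others in the source may bear on it.

Measured so far:
compound 1 `CCn1ncc(-c2nc3c(N4CCC(n5c(=O)[nH]c6ncccc65)CC4)ncnc3n2C)c1C`: 90 L/kg
compound 2 `CCn1ncc(-c2nc3c(O[C@H]4CCN(C(=O)C5CC5)C4)ncnc3n2C)c1C`: 2 L/kg

In an ADME assay (Canis lupus familiaris, strain Beagle) for pharmacokinetics (on this read-out lower numbers stand for narrower distribution and higher numbers for wider distribution into tissues), compound 1 gives 90 L/kg. Compound 2 stands at the lower of the two numbers; in this assay compound 2 gives 2 L/kg, and the gap to compound 1 lies beyond the scatter. Compound 3 `CCn1ncc(-c2nc3c(O[C@H]4CCN(C(=O)C5CCOCC5)C4)ncnc3n2C)c1C` is not yet measured. It differs from compound 2 in one place: oxan-4-yl in place of cyclopropyl on a carbonyl carbon. For the measured compounds named here, no measured pair carries such a change, so the data fix no direction. For compound 3 the expected step is a 1.3-fold lower number from compound 2 to compound 3 (0.10 log units; within the scatter), likely within the scatter. The estimate for compound 3 is 1.6 L/kg, with a range from 0.6 L/kg to 4 L/kg.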

Compound 3, volume of distribution: 3 L/kg
The estimate for compound 3 lay 1.9-fold (0.27 log units) below the measured number; the measured number falls inside the stated range.
By their numbers in this assay, from the lowest: compounds 2 and 3 (each within the scatter of the next); then compound 1.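

In this assay, for the compounds shown here, oxan-4-yl in place of cyclopropyl on a carbonyl carbon gives a 1.5-fold higher number from compound 2 to compound 3 (0.18 log units; within the scatter) and is the first one-place comparison. On this carbonyl carbon, whose other neighbour is an amide-type nitrogen in a ring, a six-membered ring with one oxygen therefore reads the same as the three-membered carbon ring within the scatter. Open, going by these compounds, is whether a piperidin-4-yl group with its ring amine, or a longer chain ending in a carboxylic acid, would also stay within the scatter of compound 2 at this place. Nothing measured on these compounds accounts for this result.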